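A few compounds are considered here, and "the series" means these few. Any claim that something is new, unique, unknown or untested is made for them only; others in the source may bear on it.

In an assay for inhibition of Polyunsaturated fatty acid 5-lipoxygenase (Homo sapiens), read by HPLC, with a stated time of 10 min (a higher number here means a weaker inhibitor, a lower number a stronger inhibitor), three compounds sharing one core have been measured. Compound 1 `CCOC(=O)c1c(CSc2ccccc2OC)n(C)c2ccc(O)cc12` gives 2900 nM, compound 2 `CCOC(=O)c1c(CSc2ccccc2C(F)(F)F)n(C)c2ccc(O)cc12` gives 800 nM, and compound 3 `CCOC(=O)c1c(CSc2cccc(Cl)c2)n(C)c2ccc(O)cc12` gives 3800 nM. Compound 3 carries the highest number of the three, though its value and that of compound 1 sit within the usual scatter of one another, while against compound 2 its number is clearly higher, beyond the scatter. Among the measured steps, a 3.6-fold lower number from compound 1 to compound 2 (0.56 log units; beyond the scatter) is the only one that exceeded the scatter, and a 1.3-fold higher number from compound 1 to compound 3 (0.12 log units; within the scatter) stayed inside it. Compound 4 `CCOC(=O)c1c(CSc2c(C)cccc2C)n(C)c2ccc(O)cc12` differs from compound 3 by 2,6-dimethylphenyl in place of 3-chlorophenyl on a sulfur. Among the measured compounds shown here, the step from compound 1 to compound 3, which also swapped the whole ring on the sulfur, is the one that bears on this change and it was small; no measured compound carries a methyl on that ring, so the new substituents are uncharted. For compound 4 a step of a 1.5-fold lower number from compound 3 to compound 4 (0.18 log units; within the scatter) in this assay is therefore expected, hardly beyond the scatter. Compound 4 is estimated at 2500 nM, with a range from 800 nM to 8000 nM.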

Compound 4, half-maximal inhibitory concentration: 800 nM
Compound 4: middle estimate off by 3.1-fold (0.49 log units), on the high side; measured number inside the range.
By their numbers in this assay, from the lowest: compounds 2 and 4 (each within the scatter of the next); then compounds 1 and 3 (each within the scatter of the next).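

The aromatic ring on the sulfur turns out to be a place where swapping the whole ring can move the number in this assay beyond the scatter: 2,6-dimethylphenyl gives a 4.8-fold lower number from compound 3 to compound 4 (0.68 log units; beyond the scatter) and also a 3.6-fold lower number from compound 1 to compound 4 (0.56 log units; beyond the scatter) in place of 2-methoxyphenyl. The earlier swap to 3-chlorophenyl stayed within the scatter, so ring changes at this sulfur do not all count alike, and compound 4 at 800 nM now matches the trifluoromethyl-bearing compound 2 at 800 nM in its printed value. Nothing available explains why the number moved with this change.

The compounds shown leave open whether a single methyl, as in 2-methylphenyl, would give the same number as the pair of methyls. They also leave open how this ring would read with an amine or a carboxylic acid on it.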